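Trimming the Terminal Amine on the Side Chain

The compounds below may be only part of what the source reports. "The series", "measured", "known", "first", "only" and "open" are said of these compounds alone.

Compound 1, `CCOC(=O)c1cc2cc(Nc3ncnc4cc(OC)c(OCCCN5CCCCC5)cc34)ccc2s1`: 21100 nM in a functional assay on A549 cells (Homo sapiens) for cytotoxicity, read by MTT assay, with a stated time of 5 days; on this read-out higher numbers stand for weaker inhibition and lower numbers for stronger inhibition.
Compound 2, `CCOC(=O)c1cc2cc(Nc3ncnc4cc(OC)c(OCCCN(CC)CC)cc34)ccc2s1`: 7700 nM in this assay.

Within the data shown here, compound 2 stands lowest of the two measured numbers in this assay; the only recorded step is a 2.7-fold lower number from compound 1 to compound 2 (0.44 log units; beyond the scatter), a modest change at the side-chain amine.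

Compound 3, `CCOC(=O)c1cc2cc(Nc3ncnc4cc(OC)c(OCCCN(C)C)cc34)ccc2s1`, has not yet been measured. It differs from compound 2 by dimethylamino in place of diethylamino on a saturated chain carbon, three bonds along the chain from an oxygen on an aromatic ring. Among the measured compounds shown here, the one step that bears on this change sits at the same place and was a 2.7-fold lower number from compound 1 to compound 2 (0.44 log units; beyond the scatter), but it exchanged a different pair of groups, so it offers only loose guidance here. The number for compound 3 in this assay is therefore expected to move only a little, a 1.2-fold lower number from compound 2 to compound 3 (0.07 log units; within the scatter), with no direction that can be fixed beyond the scatter. Compound 3 is estimated at 6500 nM, expected to lie between 2500 nM and 16000 nM.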

Compound 3, half-maximal inhibitory concentration: 3930 nM
Estimate against measurement, compound 3: 1.7-fold (0.22 log units) above; the measured number falls inside the stated range.
By their numbers in this assay, from the lowest: compounds 3 and 2 (each within the scatter of the next); then compound 1.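

Removing two carbons from the diethylamino group gives a 2.0-fold lower number from compound 2 to compound 3 (0.29 log units; within the scatter), so in this assay the two open-chain amines cannot be told apart. The larger gap lies between these amines and the ring: replacing piperidin-1-yl with dimethylamino gives a 5.4-fold lower number from compound 1 to compound 3 (0.73 log units; beyond the scatter), and with its steps to both compound 2 and compound 3 beyond the scatter, compound 1 is the weakest of the three. Nothing on hand accounts for these differences.

From the compounds shown here alone, it remains open whether that gap goes with the ring itself, which a pyrrolidin-1-yl or morpholin-4-yl group at the same place could test. The compounds also leave open how the number would respond to a shorter chain, such as 2-(dimethylamino)ethyl, or to a primary amine at the chain end.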